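Swapping the Pyridyl Ring for an Amide

This account rests on a few compounds, and the source may have more. Where it says the series, first, only, none or still open, it means among the compounds named here.

Of the compounds shown here, two share one core and have been measured. Compound 1 `CNC(=O)/C=C/c1ccc2noc(-c3ccccc3)c2c1` in an assay for inhibition of inositol hexakisphosphate kinase 2 (Homo sapiens), read by colorimetric assay, coupled enzyme assay and malachite green, with a stated time of 120 min, in the presence of a further agent that is not named here (a lower number here means a stronger inhibitor, a higher number a weaker inhibitor), gives 58200 nM. Compound 2 `O=C(O)c1ccc2noc(-c3ccc(-c4ccncc4)cc3)c2c1` in this assay gives 150 nM, the lower of the two numbers, with compound 1 far higher, well beyond the usual scatter. Compound 3 `CC(C)C(=O)Nc1ccc(-c2onc3ccc(C(=O)O)cc23)cc1` is not yet measured. It differs from compound 2 by (isopropylcarbonyl)amino in place of pyridin-4-yl on an aromatic carbon. Among the compounds with values here, no measured pair shows such a swap, so the size of the step is open. The step is expected to be a modest move toward a higher number, a 2.7-fold higher number from compound 2 to compound 3 (0.43 log units; beyond the scatter). Compound 3 is expected to give about 400 nM, somewhere between 100 nM and 1500 nM.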

Compound 3, half-maximal inhibitory concentration: 820 nM
Beside the measured number, compound 3's estimate is 2.1-fold (0.31 log units) below it; the range from low to high includes it.
By their numbers in this assay, from the lowest: compound 2; then compound 3; then compound 1.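

Placing (isopropylcarbonyl)amino in place of pyridin-4-yl on this aromatic carbon gives a 5.5-fold higher number from compound 2 to compound 3 (0.74 log units; beyond the scatter) in this assay, so the swap weakens inhibition. Even so, a ring is not essential at this position, para to a large group, since compound 3, with no ring in the new group, still gives 820 nM. No measurement at hand explains the loss. From the compounds shown here alone, whether an amine, a longer acyl chain or a pyridin-3-yl group here would match pyridin-4-yl remains open. So does whether the amide hydrogen matters, which a methylated amide nitrogen could test.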